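The compounds below may be only part of what the source reports. "The series", "measured", "known", "first", "only" and "open" are said of these compounds alone.

Compound 1, `CO[C@@]12CCN(C)C[C@H]1[C@H](c1ccc(Cl)cc1)C(C#N)=C(N)O2`: 370000 nM
Compound 2, `CCN1CC[C@@]2(OC)OC(N)=C(C#N)[C@@H](c3cccs3)[C@@H]2C1`: 490000 nM

In a functional assay (thoracic aorta, strain Wistar) for inhibition, with Rattus norvegicus as the target (a higher number here means a weaker inhibitor, a lower number a stronger inhibitor), compound 1 gives 370000 nM and compound 2 gives 490000 nM; the two numbers lie within the scatter of each other, so neither compound stands apart. Compound 3, `CO[C@@]12CCN(C)C[C@H]1[C@H](c1ccc(N3CCCCC3)cc1)C(C#N)=C(N)O2`, differs from compound 1 in one place: piperidin-1-yl in place of chloro on an aromatic carbon. Within the data shown here, no step between measured compounds resembles this change, so the data give no direction for it; a step no larger than the scatter in this assay is expected, in either direction. Compound 3 is therefore estimated at 330000 nM, with a range from 100000 nM to 1000000 nM. The step this estimate implies is expected to be a 1.1-fold lower number from compound 1 to compound 3 (0.05 log units; within the scatter).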

Compound 3, half-maximal inhibitory concentration: 450000 nM
Estimate against measurement, compound 3: 1.4-fold (0.13 log units) below, and the stated range covers the measured number.
By their numbers in this assay, from the lowest: compounds 1, 3 and 2 (each within the scatter of the next).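

Replacing chloro with piperidin-1-yl on the aromatic carbon in this assay gives a 1.2-fold higher number from compound 1 to compound 3 (0.09 log units; within the scatter). This position on the core of compound 1 therefore accepts a ring-bearing amine group in place of a single halogen without a change in the read-out beyond the scatter. No measurement shown bears on why the two groups read alike.

Going by these compounds, it remains open whether a carboxylic acid, a methoxy group or an open-chain dimethylamino group at this place would read any differently. On these data alone, it also remains open whether any group here can move the number beyond the scatter.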